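The compounds below may be only part of what the source reports. "The series", "measured", "known", "first", "only" and "open" are said of these compounds alone.

Working notes on the series in a functional assay on RKO cells (Homo sapiens) for inhibition, read by MTT assay, with a stated time of 48 h; a higher number here means a weaker inhibitor, a lower number a stronger inhibitor. Compound 1 `COc1ccc(N(C)c2nc(C)nc3ccccc23)cc1C(=O)OCC[Se]C#N` gives 2390 nM, compound 2 `COc1ccc(N(C)c2nc(C)nc3ccccc23)cc1C(=O)OCCCC[Se]C#N` gives 1020 nM and compound 3 `COc1ccc(N(C)c2nc(C)nc3ccccc23)cc1OCCN` gives 343 nM, so compound 2 holds the middle place of the three numbers. The next member is compound 4 `COc1ccc(N(C)c2nc(C)nc3ccccc23)cc1C(=O)OCCCCC[Se]C#N`, which differs from compound 2 by a group of 4 heavy atoms (2 carbon, 1 nitrogen, 1 selenium; no ring) in place of a group of 3 heavy atoms (1 carbon, 1 nitrogen, 1 selenium; no ring), on a saturated chain carbon, four bonds along the chain from an oxygen next to a carbonyl group.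

Among the compounds with values here, the closest precedent is the earlier change on the same chain, a 2.3-fold lower number from compound 1 to compound 2 (0.37 log units; beyond the scatter). The two other measured steps, a 7.0-fold lower number from compound 1 to compound 3 (0.84 log units; beyond the scatter) and a 3.0-fold lower number from compound 2 to compound 3 (0.47 log units; beyond the scatter), replace the whole group on the aromatic carbon and bear only weakly on a chain change. One step on this chain shows no trend, and the new change is smaller than that precedent. In this assay, a small move towards a lower number is therefore expected, quite possibly not beyond the scatter. The expected size is a 1.3-fold lower number from compound 2 to compound 4 (0.11 log units; within the scatter). The estimate for compound 4 is 800 nM, with an expected range from 380 nM to 1700 nM.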

Compound 4, half-maximal inhibitory concentration: 356 nM
For compound 4 the middle estimate is 2.2-fold (0.35 log units) above the measured one; measured number below the stated range.
By their numbers in this assay, from the lowest: compounds 3 and 4 (each within the scatter of the next); then compound 2; then compound 1.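

In this assay, lengthening the chain at the saturated chain carbon, four bonds along the chain from an oxygen next to a carbonyl group, gives a 2.9-fold lower number from compound 2 to compound 4 (0.46 log units; beyond the scatter), a second move in the same direction as a 2.3-fold lower number from compound 1 to compound 2 (0.37 log units; beyond the scatter). Across the chain compounds 1, 2 and 4, the number falls with each added length, none of the three goes against this, and the whole change is a 6.7-fold lower number from compound 1 to compound 4 (0.83 log units; beyond the scatter). The chain end therefore still responds at this length, and compound 4 at 356 nM stands within the scatter of compound 3 at 343 nM.

No supporting data bear on why the longer chain gives the lower number. From the compounds shown here alone, it remains open whether a still longer chain continues this fall, and whether an amine or a carboxylic acid at the chain end would hold the number of compound 4.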